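Notes on the amide nitrogen in this dihydroxy-methoxy series

A few compounds are considered here, and "the series" means these few. Any claim that something is new, unique, unknown or untested is made for them only; others in the source may bear on it.

Measured in a functional assay on the whole organism (strain Wistar) for inhibition, with Rattus norvegicus as the target, read by paw edema, with stated times of 60 min and 6 h, at a dose of 100 mg/kg by the oral route; a lower number here means less inhibition, a higher number more inhibition at the dose given (going by the name of the read-out):
Compound 1, `COc1cc2c(cc1OC)C(CC(=O)O)CC2`: 20.4%
Compound 2, `COc1cc2c(cc1OC)C(CC(=O)N(C)C)CC2`: 33.3%
Compound 3, `CCNC(=O)CC1CCc2cc(OC)c(OC)cc21`: 20.4%

Compound 3 stands level with compound 1 in this assay, the two together the lowest of the three numbers; compound 2 sits above both, a number 12.9 percentage points lower from compound 2 to compound 3 (beyond the scatter) and a number 12.9 percentage points higher from compound 1 to compound 2 (beyond the scatter). Compound 4, `CCN(CC)C(=O)CC1CCc2cc(OC)c(OC)cc21`, differs from compound 3 by ethyl in place of hydrogen on an amide-type nitrogen. The step bearing on this is the one from the tertiary amide of compound 2 to the secondary amide of compound 3, a number 12.9 percentage points lower from compound 2 to compound 3 (beyond the scatter), while no change at the digits printed from compound 1 to compound 3 (within the scatter). Returning to a tertiary amide is therefore expected to give a modest rise, a number 9.6 percentage points higher from compound 3 to compound 4 (within the scatter). Compound 4 is expected to give 30%, with a range of 15% to 45%.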

Compound 4, a percentage reported as inhibition, in the whole organism at one dose (the size of the read-out at that dose, not a potency): 31.5%
Beside the measured number, compound 4's estimate is 1.5 percentage points below it; the range from low to high includes it.
By their numbers in this assay, from the lowest: compounds 1 and 3 (each within the scatter of the next); then compounds 4 and 2 (each within the scatter of the next).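

In this assay, ethyl in place of the amide hydrogen gives a number 11.1 percentage points higher from compound 3 to compound 4 (beyond the scatter), so a second ethyl on the nitrogen changes the number where the first, set against the acid, did not; against the acid itself the diethylamino amide shows a number 11.1 percentage points higher from compound 1 to compound 4 (beyond the scatter). The size of the alkyl pair on the tertiary amide does not register, with a number 1.8 percentage points lower from compound 2 to compound 4 (within the scatter). Nothing at hand bears on the origin of this difference.

Still open, on these data alone, is whether the rise holds for a longer chain such as dipropylamino, or for a nitrogen closed into a pyrrolidine ring. As far as these compounds go, the plain primary amide also remains open.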